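Swapping the Group on the Ring Nitrogen

A few compounds are considered here, and "the series" means these few. Any claim that something is new, unique, unknown or untested is made for them only; others in the source may bear on it.

Three compounds share one core and differ only in the group on an amine nitrogen in a ring. In an ADME assay on HEK293 cells (Homo sapiens) for cytotoxicity, read by MTT assay, with a stated time of 48 h (a lower number here means a stronger inhibitor, a higher number a weaker inhibitor), compound 1 `COc1ccc(-c2cn3cc(C4=CCN(C(=O)c5cccc(C(F)(F)F)c5)CC4)ccc3n2)cc1OC` gives 68400 nM, compound 2 `COc1ccc(-c2cn3cc(C4=CCN(S(=O)(=O)C5CCCCC5)CC4)ccc3n2)cc1OC` gives 75000 nM, and compound 3 `COc1ccc(-c2cn3cc(C4=CCN(S(=O)(=O)CCc5ccccc5)CC4)ccc3n2)cc1OC` gives 70300 nM, the second highest of the three numbers, with both neighbours within the scatter. The steps of a 1.1-fold higher number from compound 1 to compound 2 (0.04 log units; within the scatter), a 1.0-fold higher number from compound 1 to compound 3 (0.01 log units; within the scatter) and a 1.1-fold lower number from compound 2 to compound 3 (0.03 log units; within the scatter) each changed this position and each stayed within the scatter. Compound 4 `COc1ccc(-c2cn3cc(C4=CCN(C(=O)c5cccs5)CC4)ccc3n2)cc1OC` differs from compound 3 by (thiophen-2-yl)carbonyl in place of phenethylsulfonyl on an amine nitrogen in a ring. Since every earlier change at this position left this assay unmoved, for compound 4 a step of a 1.0-fold lower number from compound 3 to compound 4 (0.00 log units; within the scatter) is expected, nothing beyond the scatter. Compound 4 is therefore estimated at 70000 nM, within a range from 35000 nM to 140000 nM.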

Compound 4, half-maximal inhibitory concentration: 98100 nM
Compound 4: middle estimate off by 1.4-fold (0.15 log units), on the low side; the range from low to high includes it.
By their numbers in this assay, from the lowest: compounds 1, 3, 2 and 4 (each within the scatter of the next).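

In this assay, a five-membered aromatic ring with one hetero atom also stays within the scatter of all three earlier compounds, with a 1.4-fold higher number from compound 3 to compound 4 (0.14 log units; within the scatter) and a 1.3-fold higher number from compound 2 to compound 4 (0.12 log units; within the scatter) and, with the carbonyl kept and only the ring on it exchanged, a 1.4-fold higher number from compound 1 to compound 4 (0.16 log units; within the scatter). The amine nitrogen in the ring has now carried both six-membered and five-membered rings, on a carbonyl or on a sulfonyl, with no step beyond the scatter. Nothing available explains this flat picture.

The compounds shown leave open whether a group carrying an amine or a carboxylic acid, or a plain hydrogen on that nitrogen, would give a step beyond the scatter in this assay.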